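The compounds below may be only part of what the source reports. "The series", "measured", "known", "first", "only" and "open" are said of these compounds alone.

Compound 1 `O=C(NC(=S)Nc1ccc(F)cc1)c1cn(-c2ccccc2)nc1-c1ccc(F)cc1`: 3540 nM
Compound 2 `Cc1ccc(NC(=S)NC(=O)c2cn(-c3ccccc3)nc2-c2ccccc2)cc1`: 2800 nM
Compound 3 `COc1ccc(NC(=S)NC(=O)c2cn(-c3ccccc3)nc2-c2ccc(OC)cc2)cc1`: 750 nM

Of the compounds shown here, three sharing one core have been measured in a functional assay on A549 cells (Homo sapiens) for inhibition, read by CCK-8 assay, with a stated time of 48 h; a lower number here means a stronger inhibitor, a higher number a weaker inhibitor. Compound 1 gives 3540 nM, compound 2 gives 2800 nM, and compound 3 gives 750 nM. Compound 2 stands close to compound 1; the gap between them lies within the scatter of repeated measurement, so no order between these two can be read. Against compound 3 the gap is beyond the scatter, and compound 3 gives the lower number of the two.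

Compound 4 `Cc1ccc(NC(=S)NC(=O)c2cn(-c3ccccc3)nc2-c2ccc(C)cc2)cc1` has not yet been measured in this assay. It differs from compound 2 by methyl in place of hydrogen on an aromatic carbon. Within the data shown here, no pair of measured compounds differs in exactly this one place, so the size of such a step is not known from a direct comparison. The expectation rests only on the three numbers shown: compound 3, which bears a group on each of its two phenyl rings, gives 750 nM, while compound 2 with one bare phenyl gives 2800 nM. Compound 4 is therefore expected to give a somewhat lower number than compound 2, a step of a 1.6-fold lower number from compound 2 to compound 4 (0.19 log units; within the scatter), though a step that stays within the scatter would not be surprising. The estimated value for compound 4 is 1800 nM, with a range from 800 nM to 4000 nM.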

Compound 4, half-maximal inhibitory concentration: 2830 nM
For compound 4 the middle estimate is 1.6-fold (0.20 log units) below the measured one, and the stated range covers the measured number.
By their numbers in this assay, from the lowest: compound 3; then compounds 2, 4 and 1 (each within the scatter of the next).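

In this assay, the change from phenyl to 4-methylphenyl gives a 1.0-fold higher number from compound 2 to compound 4 (0.00 log units; within the scatter), so methyl in place of hydrogen at this place leaves no readable mark on the number. Among these compounds, this is the first single change that can be read directly, and it shows that adding this one carbon, para to a large group, does not by itself separate the two compounds. Nothing at hand offers an explanation for so flat a step, and no cause can be given for it.

The compounds shown leave open whether a different group at this place, such as an amine, a carboxylic acid or a longer chain, would move the number at all. They also leave open whether the methyl step would read the same with other groups elsewhere on the shared core.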